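A few compounds are considered here, and "the series" means these few. Any claim that something is new, unique, unknown or untested is made for them only; others in the source may bear on it.

Working notes on the series. Three compounds of the shared core have numbers in a functional assay on NCI-H460 cells (Homo sapiens) for inhibition, read by MTT assay, with a stated time of 72 h; a higher number here means a weaker inhibitor, a lower number a stronger inhibitor. Compound 1 `CCN(CC)CCCn1c(=O)c(=Cc2cc(OC)c(OC)c(OC)c2)s/c1=C1\C(=O)Nc2ccc(C)cc21` gives 2670 nM. Compound 2 `CCN(CC)CCCn1c(=O)c(=Cc2ccc(F)c(F)c2)s/c1=C1\C(=O)Nc2cc(F)ccc21` gives 1120 nM. Compound 3 `CCN(CC)CCCn1c(=O)c(=Cc2ccc(F)cc2F)s/c1=C1\C(=O)Nc2ccc(Cl)cc21` gives 6100 nM, the highest number of the three and therefore the weakest inhibitor among them; its gap to compound 1 is the smaller of its two gaps and its gap to compound 2 the larger, and both lie beyond the usual scatter of repeated measurements.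

Compound 4 `CCN(CC)CCCn1c(=O)c(=Cc2cc(OC)c(OC)c(OC)c2)s/c1=C1\C(=O)Nc2ccc(Cl)cc21` has not yet been measured. It differs from compound 3 in one place: 3,4,5-trimethoxyphenyl in place of 2,4-difluorophenyl on a double-bonded chain carbon bound to an aromatic carbon. Compound 1 also carries the 3,4,5-trimethoxyphenyl but differs from compound 4 elsewhere as well, so no single change between two measured compounds mirrors this step, and the size of the step has to be judged from the three numbers alone.

Expectation: the number for compound 4 in this assay is expected to move downward from that of compound 3, toward the region where compound 1 stands, and the step from compound 3 to compound 4 is estimated as a 2.0-fold lower number from compound 3 to compound 4 (0.31 log units; beyond the scatter), probably beyond the scatter but not large. Compound 4 is estimated at 3000 nM in this assay, with a range from 1000 nM to 9000 nM.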

Compound 4, half-maximal inhibitory concentration: 2990 nM
For compound 4 the middle estimate is 1.0-fold (0.00 log units) above the measured one; the range from low to high includes it.
By their numbers in this assay, from the lowest: compound 2; then compounds 1 and 4 (each within the scatter of the next); then compound 3.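

In this assay, for the compounds shown here, with the rest of the structure held fixed, 3,4,5-trimethoxyphenyl in place of 2,4-difluorophenyl on a double-bonded chain carbon bound to an aromatic carbon gives a 2.0-fold lower number from compound 3 to compound 4 (0.31 log units; beyond the scatter) as the first single-place reading at this position, and the step is modest in size. Chloro in place of methyl on an aromatic carbon, with the 3,4,5-trimethoxyphenyl kept, gives a 1.1-fold higher number from compound 1 to compound 4 (0.05 log units; within the scatter) and so shows no readable difference between these two groups in this setting. No measurement at hand accounts for the direction or size of either step.

Going by these compounds, the aryl step is read only with chloro on the core, and the chloro and methyl comparison only with 3,4,5-trimethoxyphenyl, so it stays open whether either reading carries over to the other partner group. Also open, on these data alone, is how an unsubstituted phenyl or a pyridine ring at the aryl position would stand, and how a morpholine in place of the diethylamine at the end of the chain would stand.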